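A few compounds are considered here, and "the series" means these few. Any claim that something is new, unique, unknown or untested is made for them only; others in the source may bear on it.

Measured compounds:
compound 1 `CCN(CC)CCCOc1cc2ncnc(Nc3ccc(C#N)cc3)c2cc1OC`, 50600 nM in a functional assay on A549 cells (Homo sapiens) for antiproliferative activity, read by MTT assay, with a stated time of 72 h; a higher number here means a weaker inhibitor, a lower number a stronger inhibitor
compound 2 `COc1cc2c(Nc3ccc(C#N)cc3)ncnc2cc1OCCCN1CCC(C)CC1`, 32300 nM

Compound 1 stands next to compound 2, since the step of a 1.6-fold lower number from compound 1 to compound 2 (0.19 log units; within the scatter) lies within the scatter. Compound 3 `CCN1CCN(CCCOc2cc3ncnc(Nc4ccc(C#N)cc4)c3cc2OC)CC1` differs from compound 1 in one place: 4-ethylpiperazin-1-yl in place of diethylamino on a saturated chain carbon, three bonds along the chain from an oxygen on an aromatic ring. For the measured compounds named here, the only measured step that bears on this is the one from compound 1 to compound 2, where one amine gave way to another at the same place with no change beyond the scatter. A similar outcome is expected here, so compound 3 is estimated at 35000 nM, with a range of 15000 nM to 80000 nM, meaning an expected step of a 1.4-fold lower number from compound 1 to compound 3 (0.16 log units; within the scatter).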

Compound 3, half-maximal inhibitory concentration: 16000 nM
Compound 3: middle estimate off by 2.2-fold (0.34 log units), on the high side, and the stated range covers the measured number.
By their numbers in this assay, from the lowest: compound 3; then compounds 2 and 1 (each within the scatter of the next).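

In this assay, 4-ethylpiperazin-1-yl at this place gives a 3.2-fold lower number from compound 1 to compound 3 (0.50 log units; beyond the scatter) and a 2.0-fold lower number from compound 2 to compound 3 (0.31 log units; beyond the scatter). Both steps are modest but lie beyond the scatter, so the choice of amine on this chain can change the number, which the earlier swap of diethylamino for 4-methylpiperidin-1-yl did not show. No measurement at hand explains this step.

The compounds shown leave open whether a morpholine or an unsubstituted piperazine would behave like 4-ethylpiperazin-1-yl. They also leave open whether the step would hold on a longer chain.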